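The compounds below may be only part of what the source reports. "The series", "measured", "known", "first", "only" and "open" are said of these compounds alone.

Measured so far in a functional assay on the whole organism for inhibition, with Rattus norvegicus as the target, read by paw edema, in the formalin test, with a stated time of 2 h, at a dose of 100 mg/kg by the intraperitoneal route; on this read-out lower numbers stand for less inhibition and higher numbers for more inhibition at the one dose given (going by the name of the read-out):
- compound 1 `O=c1cc(CNc2nc(-c3cc4cc(Br)cc(Br)c4oc3=O)cs2)c2cc(Cl)ccc2[nH]1`: compound 1 gives 17.8%
- compound 2 `O=c1cc(CNc2nc(-c3cc4cc(Br)cc(Br)c4oc3=O)cs2)c2ccc(Cl)cc2[nH]1`: compound 2 gives 13%

Compound 1 and compound 2 share the whole core and differ only in where the chloro group sits on one ring of it. Among the compounds with values here, compound 1 stands first of the two numbers, but the gap to compound 2 lies within the usual scatter of this assay, so the two readings cannot be told apart, and no step between them is recorded. Both numbers are low, which is all that can be said of the series at present.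

The next compound, compound 3 `O=c1cc(CNc2nc(-c3cc4cc(Br)ccc4oc3=O)cs2)c2cc(Cl)ccc2[nH]1`, keeps the core of compound 1 and makes one change: hydrogen in place of bromo on an aromatic carbon. Within the data shown here, no pair among the measured compounds shows what removing a bromo group does here, so the size of this step has no precedent. With two low readings that sit within the scatter of each other, the expectation is no step beyond the scatter in this assay, in either direction. Compound 3 is therefore expected to give 15%, between 5% and 28%, an estimated step of a number 2.8 percentage points lower from compound 1 to compound 3 (within the scatter) that stays inside the scatter.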

Compound 3, a percentage reported as inhibition, in the whole organism at one dose (the size of the read-out at that dose, not a potency): 5.26%
Estimate against measurement, compound 3: 9.7 percentage points above, within the range that was stated.
By their numbers in this assay, from the lowest: compounds 3, 2 and 1 (each within the scatter of the next, the first and the last beyond it).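

In this assay, within the data shown here, hydrogen in place of bromo on an aromatic carbon, ortho to a fused ring and meta to a bromo group, gives the first readable step: a number 12.5 percentage points lower from compound 1 to compound 3 (beyond the scatter). The earlier compounds shown here differed only in where the chloro group sits and gave no reading on the bromo groups, whereas this pair ties a modest loss of inhibition at the one dose given to this single bromo group, with the other bromo group and the rest of the core of compound 1 unchanged. Nothing at hand bears on why the reading moves with this change, and a single pair at a single dose gives the size of the step and no more.

On these data alone, it remains open whether a methoxy group, an amine or a carboxylic acid on this same aromatic carbon would keep the reading near that of compound 1 or bring it down to that of compound 3. Also open, as far as these compounds go, are what hydrogen in place of the other bromo group would do and whether this step would carry over to the chloro arrangement of compound 2.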